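The source may report more compounds than this note shows. Statements on the series, on what has been measured and on what is new or still open speak of the compounds shown alone.

Compound 1 `O=C(Nc1ccccc1)Nc1nc2ccc(F)cc2s1`: > 10 ug/mL
Compound 2 `O=C(Nc1cccc([N+](=O)[O-])c1)Nc1nc2ccc(F)cc2s1`: 0.89 ug/mL
Compound 3 `COc1cccc2sc(NC(=O)c3ccc([N+](=O)[O-])cc3)nc12`: > 10 ug/mL

In a functional assay on MDA-MB-231 cells (Homo sapiens) for antiproliferative activity, read by sulforhodamine B assay (on this read-out lower numbers stand for stronger inhibition of growth and higher numbers for weaker inhibition of growth), compound 1 gives > 10 ug/mL, which is a limit of the assay and not a number. Compound 3 likewise gives > 10 ug/mL, again a limit. Compound 2 gives the only number shown, 0.89 ug/mL, and so stands alone as the one measured point; the two other values sit at the limit of > 10 ug/mL in this assay, at which 2 of the 3 values shown sit.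

Compound 4 `O=C(Nc1cccc([N+](=O)[O-])c1)Nc1nc2ccc(Cl)cc2s1` differs from compound 2 in one place: chloro in place of fluoro on an aromatic carbon. For the measured compounds named here, the single measured step, an at least 11-fold lower number from compound 1 to compound 2 (1.05 log units; beyond the scatter), concerns the nitro group rather than the halogen on the fused ring, so it does not bear directly on this change. No step beyond the scatter is therefore expected here, and the step of a 1.3-fold lower number from compound 2 to compound 4 (0.10 log units; within the scatter) is expected to stay small. Compound 4 is estimated at 0.7 ug/mL, between 0.2 ug/mL and 2.5 ug/mL.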

Compound 4, concentration for 50% growth inhibition: 0.82 ug/mL
Compound 4: the middle estimate sits 1.2-fold (0.07 log units) below what was measured; the measured number falls inside the stated range.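

For the compounds shown here, the only earlier step concerned the nitro group and said nothing about the halogen on the shared core. In this assay, the step is a 1.1-fold lower number from compound 2 to compound 4 (0.04 log units; within the scatter), so with the nitro group in place, chloro and fluoro on this aromatic carbon of the six-membered ring cannot be told apart. Nothing given here explains why the two halogens read alike.

Still open, going by these compounds, is whether this position accepts anything other than a small halogen, such as an amine, a carboxylic acid or a longer chain. On these data alone, whether bromo would read the same also remains unknown.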